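Hydrogen for Methyl on the Ring Urea Nitrogen

The source may hold more compounds than are shown below. What is called first, only, known or untested is meant among the compounds shown, and "the series" means these compounds.

Measured so far:
compound 1 `CN1CCN(CCOc2nn(-c3ccccc3F)c3ccc(F)cc23)C1=O`: 1000 mL/min/kg
compound 2 `O=C1C2CN(Cc3ccccc3)CC2CN1c1cccc2c1cnn2-c1ccccc1F`: 900 mL/min/kg

Both compounds were tested in an ADME assay on liver for metabolic stability, with Liver microsome (Homo sapiens) as the target, using microsomes and NADPH, with a stated time of 30 min, tested at 0.5 uM; a higher number here means faster removal of the compound, a lower number slower removal. Compound 1 gives 1000 mL/min/kg, the higher of the two numbers, while compound 2 gives 900 mL/min/kg. The gap between them lies within the scatter of repeated measurements, so the two compounds cannot be told apart on these data, and neither can be called the more stable of the pair.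

Compound 3 `O=C1NCCN1CCOc1nn(-c2ccccc2F)c2ccc(F)cc12` is not yet measured in this assay. It differs from compound 1 in one place: hydrogen in place of methyl on an amide-type nitrogen in a ring. Among the compounds with values here, no step between two measured compounds with this same change is available, so there is no direct precedent for how large an effect to expect.

The account expects a modest drop, if any, for compound 3, estimated at 700 mL/min/kg with a range from 300 mL/min/kg to 1100 mL/min/kg. The expected step of a 1.4-fold lower number from compound 1 to compound 3 (0.15 log units; within the scatter) is small and may well stay within the scatter.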

Compound 3, clearance: 183 mL/min/kg
For compound 3 the middle estimate is 3.8-fold (0.58 log units) above the measured one; measured number outside the range, below it.
By their numbers in this assay, from the lowest: compound 3; then compounds 2 and 1 (each within the scatter of the next).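

In this assay, the methyl on the amide-type nitrogen of the five-membered ring proves to matter: hydrogen in its place gives a 5.5-fold lower number from compound 1 to compound 3 (0.74 log units; beyond the scatter) and so moves the number beyond the scatter. Within the data shown here, until now no step between measured compounds was available, and this first one shows that removing a single carbon from the 2-(3-methyl-2-oxoimidazolidin-1-yl)ethyl group, with the core of compound 1 untouched, is enough to change the rate of removal clearly. The compounds shown hold no measurement that bears on why the number falls with this change.

Going by these compounds, a single step cannot separate the loss of the methyl from the presence of the amide hydrogen, and it remains open whether an ethyl or an acetyl group on the same nitrogen would give a number nearer that of compound 1 or that of compound 3. On these data alone, it also remains open whether hydrogen in place of methyl at this nitrogen would lower the number to a similar degree on another core, or with a longer chain in place of the 2-(2-oxoimidazolidin-1-yl)ethyl group.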